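Benzoxazole cap replaced by a fluorophenyl cap

This account rests on a few compounds, and the source may have more. Where it says the series, first, only, none or still open, it means among the compounds named here.

Compound 1 `O=C(CCCCCCNC(=O)C(O)(O)C(F)(F)F)Nc1nc2ccccc2o1`: 3450 nM
Compound 2 `O=C(CCCCCCNC(=O)C(O)(O)C(F)(F)F)Nc1nc2ccc(Br)cc2o1`: 12100 nM
Compound 3 `CC(=O)C(=O)NCCCCC(=O)Nc1ccccc1`: limit > 100000 nM

In a functional assay on HCT-116 cells (Homo sapiens) for inhibition, read by colorimetric assay, with a stated time of 3 days (on this read-out higher numbers stand for weaker inhibition and lower numbers for stronger inhibition), compound 1 gives 3450 nM, the lowest of the two numbers shown. Compound 2 gives 12100 nM; the step of a 3.5-fold higher number from compound 1 to compound 2 (0.54 log units; beyond the scatter). Compound 3 reaches only a limit in this assay, > 100000 nM, which is a limit of the assay and not a number (the limit of > 100000 nM in this assay, at which 1 of the 3 values shown sits).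

Compound 4 `O=C(CCCCCCNC(=O)C(O)(O)C(F)(F)F)Nc1ccc(F)cc1` differs from compound 1 in one place: 4-fluorophenyl in place of 1,3-benzoxazol-2-yl on an amide-type nitrogen. Going by the values given here, no measured step touches the group on the amide-type nitrogen; the only measured step concerns a bromo in place of hydrogen on an aromatic carbon and does not bear on this change. Among the compounds with values here, compound 3 carries a phenyl on its amide-type nitrogen but differs from compound 1 in several other places, so its limit shows only that such a compound can fall out of range. The expected step of a 4.3-fold higher number from compound 1 to compound 4 (0.64 log units; beyond the scatter) is therefore towards a higher number, beyond the scatter. Compound 4 is estimated at 15000 nM, with a range from 4000 nM to 60000 nM.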

Compound 4, half-maximal inhibitory concentration: 7570 nM
Compound 4: middle estimate off by 2.0-fold (0.30 log units), on the high side; the range from low to high includes it.
By their numbers in this assay, from the lowest: compound 1; then compounds 4 and 2 (each within the scatter of the next). At a limit, above all of these: compound 3.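

In this assay the group on the amide-type nitrogen can be exchanged at a modest cost, with a step of a 2.2-fold higher number from compound 1 to compound 4 (0.34 log units; beyond the scatter) on going from 1,3-benzoxazol-2-yl to 4-fluorophenyl. The five-membered aromatic ring with its hetero atoms is therefore not needed for a measurable number, as compound 4, with one six-membered aromatic ring of carbon only, still gives a number and not a limit. Nothing measured here accounts for the size of this step.

The compounds shown leave open how a plain phenyl or a pyridine on this nitrogen would read with the rest of compound 1 unchanged, so the part played by the fluorine cannot be separated from that of the ring exchange. On these data alone, whether a shorter or longer chain would alter the picture also remains open.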